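Chloro-to-Hydrogen Swap on Two Bis-Chalcone Cores

The source may hold more compounds than are shown below. What is called first, only, known or untested is meant among the compounds shown, and "the series" means these compounds.

Compound 1: `Cc1cc(O)c(C(=O)/C=C/c2ccccc2)c(-c2ccc(Cl)cc2)c1C(=O)/C=C/c1ccccc1` — 4400 nM
Compound 2: `Cc1cc(O)c(C(=O)/C=C/c2ccccc2)c(-c2ccccc2)c1C(=O)/C=C/c1ccccc1` — 8500 nM
Compound 3: `Cc1cc(O)c(C(=O)/C=C/c2ccc3ccccc3c2)c(-c2ccc(Cl)cc2)c1C(=O)/C=C/c1ccc2ccccc2c1` — "not active" (no number reported)

In a functional assay on MDA-MB-231 cells (Homo sapiens) for cytotoxicity, read by MTT assay, with a stated time of 24 h (on this read-out higher numbers stand for weaker inhibition and lower numbers for stronger inhibition), compound 1 gives 4400 nM. Compound 2 differs from it by hydrogen in place of chloro on an aromatic carbon, and this change produced a 1.9-fold higher number from compound 1 to compound 2 (0.29 log units; within the scatter). The two values therefore cannot be told apart on this read-out.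

Compound 3 carries a different core; the difference between the two cores is not broken down here. In this assay compound 3 is reported as "not active" (no number reported), so no single number is known for it.

Compound 4, `Cc1cc(O)c(C(=O)/C=C/c2ccc3ccccc3c2)c(-c2ccccc2)c1C(=O)/C=C/c1ccc2ccccc2c1`, is not yet measured. It differs from compound 3 by hydrogen in place of chloro on an aromatic carbon, the same kind of change as that from compound 1 to compound 2, at a place described in the same words. Since that change made a step within the scatter, and since compound 3 gave no measurable number, compound 4 is expected to behave much like compound 3, with a fair chance that only a limit is reported. Compound 4 is expected to give 60000 nM, with a likely range from 15000 nM to 250000 nM.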

Compound 4, half-maximal inhibitory concentration: 30000 nM
Compound 4: middle estimate off by 2.0-fold (0.30 log units), on the high side; low and high end bracket the measured number.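

In this assay, within the data shown here, compound 4 gives 30000 nM, but compound 3 has no number, so no step between compound 3 and compound 4 can be read. The compounds shown leave open how much the change from 4-chlorophenyl to phenyl matters on the core of compound 3. No measurement here offers an explanation for this result.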